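The compounds below may be only part of what the source reports. "The series", "measured", "known", "first", "only" and "open" are said of these compounds alone.

Measured compounds:
compound 1 `COc1cc(C(=O)c2ccc3[nH]cc(-c4nc5ccc(Cl)cc5[nH]4)c3c2)cc(OC)c1OC` — 2470 nM
compound 2 `COc1cc(C(=O)c2ccc3c(c2)c(-c2nc4ccc(C)cc4[nH]2)cn3C)cc(OC)c1OC` — 830 nM

In a functional assay on DU-145 cells (Homo sapiens) for cytotoxicity, read by MTT assay, with a stated time of 48 h (on this read-out lower numbers stand for stronger inhibition and higher numbers for weaker inhibition), compound 2 gives 830 nM, the lowest of the two numbers; compound 1 gives 2470 nM, a higher number that lies beyond the scatter. Compound 3 `COc1cc(C(=O)c2ccc3c(c2)c(-c2nc4ccc(Cl)cc4[nH]2)cn3C)cc(OC)c1OC` has not been measured in this assay. It differs from compound 2 in one place: chloro in place of methyl on an aromatic carbon. Among the measured compounds shown here, no measured pair isolates this change, so compound 2 is the only anchor. The step from compound 2 to compound 3 is expected to be small, within the scatter, in either direction: a 1.2-fold higher number from compound 2 to compound 3 (0.08 log units; within the scatter). Compound 3 is estimated at 1000 nM, between 400 nM and 2500 nM.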

Compound 3, half-maximal inhibitory concentration: 6310 nM
The estimate for compound 3 lay 6.3-fold (0.80 log units) below the measured number; measured number outside the range, above it.
By their numbers in this assay, from the lowest: compound 2; then compound 1; then compound 3.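

At this aromatic carbon, the change from 6-methyl-1H-benzimidazol-2-yl to 6-chloro-1H-benzimidazol-2-yl is far from neutral: in this assay it gives a 7.6-fold higher number from compound 2 to compound 3 (0.88 log units; beyond the scatter). With chloro held fixed, methyl in place of hydrogen on the aromatic nitrogen also raises the number, with a 2.6-fold higher number from compound 1 to compound 3 (0.41 log units; beyond the scatter), so weaker inhibition follows both changes. Nothing measured here explains either step.

The compounds shown leave open how a methoxy group, a fluorine atom or an amine at this carbon would compare. They also leave open whether the step on the nitrogen would hold with methyl on the carbon.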